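The source may report more compounds than this note shows. Statements on the series, on what has been measured and on what is new or still open speak of the compounds shown alone.

Within the data shown here, in a physicochemical assay for permeability, using PAMPA (a lower number here means that the compound crosses the layer more slowly, a higher number that the compound crosses the layer faster), only one number is available so far for this small series built on a shared core. For compound 1 (`O=C(O)CCn1c(=O)oc2cc(OCc3ccccc3)c(Cl)cc21`) the entry reads "not determined" (no result reported) and offers nothing to compare. Among the measured compounds shown here, compound 2 (`O=C(O)CCn1c(=O)oc2cc(OCc3ccccn3)c(Cl)cc21`) gives 11 nm/s as the sole measured value, and it cannot yet be placed against any other compound. Compound 3 (`C[C@@H](Oc1cc2oc(=O)n(CCC(=O)O)c2cc1Cl)c1ncccn1`) is still to be measured. It differs from compound 2 in a single place, on an oxygen on an aromatic ring: a group of 8 heavy atoms (6 carbon, 2 nitrogen; one six-membered aromatic ring with 2 hetero atoms) in place of a group of 7 heavy atoms (6 carbon, 1 nitrogen; one six-membered aromatic ring with 1 hetero atom), on an oxygen on an aromatic ring (the entering group also has 1 defined stereocentre). For the measured compounds named here, no measured step between compounds exists to serve as a guide. With compound 2 at 11 nm/s as the only anchor, the shared core unchanged and a six-membered aromatic ring still present in the exchanged group, only a small shift is expected. The estimated move is a 1.4-fold lower number from compound 2 to compound 3 (0.14 log units; within the scatter) as a slight fall that should stay within the scatter. Compound 3 is expected at 8 nm/s (range 3 nm/s to 20 nm/s) in this assay once it is measured.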

Compound 3, apparent permeability: < 3 nm/s
Compound 3: a limit, no number; the forecaster's own chance of this, stated with the estimate: 15%; at least 2.6-fold (0.42 log units) between middle value and limit.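

In this assay compound 3 gives < 3 nm/s, which is a limit of the assay and not a number. Among these compounds, exchanging the (pyridin-2-yl)methyl group on this oxygen for a group with a six-membered aromatic ring with 2 hetero atoms and 1 defined stereocentre gives an at least 3.6-fold lower number from compound 2 to compound 3 (0.56 log units; beyond the scatter), the first readable step, so the read-out is sensitive to a change at this place even though a six-membered aromatic ring is kept. The size of the step remains open-ended, and only its minimum can be read, since the result for compound 3 is not a number: the limit of < 3 nm/s in this assay, at which 1 of the 3 values shown sits.

The entering group differs in both its ring hetero atoms and its defined stereocentre, so the compounds shown do not separate the contribution of one from that of the other. They also leave open how the read-out would respond to the opposite stereocentre, to an amine or a longer chain on this oxygen, or to an ester in place of the carboxylic acid.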